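This account rests on a few compounds, and the source may have more. Where it says the series, first, only, none or still open, it means among the compounds named here.

Measured so far in a functional assay on MCF7 cells (Homo sapiens) for inhibition, read by sulforhodamine B assay, with a stated time of 48 h; on this read-out lower numbers stand for stronger inhibition of growth and higher numbers for weaker inhibition of growth:
- compound 1 `CC1=CC[C@H](C(C)(C)NC(=S)N/N=C/c2ccccc2O)CC1` gives 17500 nM
- compound 2 `CC1=CC[C@H](C(C)(C)NC(=S)N/N=C/c2ccccc2[N+](=O)[O-])CC1` gives 94700 nM

Compound 1 has the lower of these two numbers. Going by the values given here, the single measured step, a 5.4-fold higher number from compound 1 to compound 2 (0.73 log units; beyond the scatter), shows that swapping the hydroxy for a nitro weakened growth inhibition. Compound 3 `CC1=CC[C@H](C(C)(C)NC(=S)N/N=C/c2ccco2)CC1` differs from compound 1 by furan-2-yl in place of 2-hydroxyphenyl on a carbon with a double bond to nitrogen, a change that likewise removes the hydroxy-bearing ring. Among the compounds with values here, only that one step bears on this change, so a weakening of broadly similar, modest size is expected: a 2.3-fold higher number from compound 1 to compound 3 (0.36 log units; beyond the scatter). Compound 3 is therefore estimated at 40000 nM, with a likely range from 15000 nM to 120000 nM in this assay.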

Compound 3, concentration for total growth inhibition: 53700 nM
The estimate for compound 3 lay 1.3-fold (0.13 log units) below the measured number, within the range that was stated.
By their numbers in this assay, from the lowest: compound 1; then compounds 3 and 2 (each within the scatter of the next).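

In this assay, the ring itself can be exchanged at this place, not only the group on it: a 3.1-fold higher number from compound 1 to compound 3 (0.49 log units; beyond the scatter). With a furan-2-yl group as with the nitro-bearing ring, the number rises, so neither replacement of 2-hydroxyphenyl matches compound 1 in this small set. Nothing available explains this rise. On these data alone, it remains open whether the hydroxy or the six-membered ring matters more, which a plain phenyl group could help to separate. A 2-aminophenyl group or a carboxylic acid on the ring could test this place further.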